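The source may report more compounds than this note shows. Statements on the series, on what has been measured and on what is new or still open speak of the compounds shown alone.

The account opens with compound 1 `C=C1CC[C@]2(C[C@@H]1OC(C)=O)[C@@H](C(=O)OCC)CC[C@H]2C(C)C` in an ADME assay on BJ cells (Homo sapiens) for cytotoxicity, with a stated time of 72 h; a higher number here means that more compound is needed for the effect, a lower number that less compound is needed. Here compound 1 returns > 90000 nM, which is a limit of the assay and not a number. Compound 2 `CC(C)[C@@H]1CC[C@H](CO)[C@]12CC[C@](C)(O)[C@H]1O[C@H]12` is the compound from which the step sets out. In this assay compound 2 returns > 90000 nM, again a limit rather than a measured value. Within the data shown here, compound 2 therefore stands only at a limit, and the one further value shown is a limit as well, so that (the limit of > 90000 nM in this assay, at which 2 of the 2 values shown sit); nothing separates the two. Compound 3 `CC(C)[C@@H]1CC[C@H](CO)[C@]12CC[C@@](C)(O)[C@H]1O[C@H]12` is the next compound and has not yet been measured in this assay. It differs from compound 2 in that (the two compounds have the same atoms and bonds and differ only in configuration as drawn: 1 of 6 stereo elements differ; a stereocentre at a saturated ring carbon is drawn S in compound 2 and R in compound 3). Among the measured compounds shown here, no step between measured compounds is at hand. With the same atoms and bonds in both, the expected step of a number no higher from compound 2 to compound 3 (the limit leaves the size open) is none beyond the scatter. Compound 3 is thus estimated at 90000 nM, with a range from 45000 nM to 200000 nM, most likely reported once more only as a limit.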

Compound 3, half-maximal effective concentration: > 90000 nM
Compound 3: only a limit was reported; the forecaster's own chance of this, stated with the estimate: 85%; the middle value lies on the limit itself.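

No step can be read from compound 2 to compound 3, since in this assay both stand only at a limit: the limit of > 90000 nM in this assay, at which 3 of the 3 values shown sit.

The compounds shown leave open whether this change of configuration alters cytotoxicity at all, and where the true values of all three compounds lie.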